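The compounds below may be only part of what the source reports. "The series", "measured", "known", "first", "only" and "open" are said of these compounds alone.

For the measured compounds named here, in a functional assay on HCT-116 cells (Homo sapiens) for inhibition, read by CCK-8 assay, with a stated time of 72 h, tested at 2 uM (a higher number here means more inhibition of growth at the concentration tested, a lower number less inhibition of growth), three compounds have numbers so far. Compound 1 `Cc1cc(C)cc(SCc2ccc(/C=C/C(=O)Nc3ccccc3N)cc2)c1` gives 7.98%, compound 3 `Nc1ccccc1NC(=O)/C=C/c1ccc(CSc2cccc3ccccc23)cc1` gives 11%, and compound 2 `Nc1ccccc1NC(=O)c1ccc(CSc2cccc(F)c2)cc1` gives 5.5%. Compound 2 therefore stands within the scatter of both others, and the three cannot be ranked. The next structure is compound 4 `Nc1ccccc1NC(=O)c1ccc(CSc2ccc(F)cc2)cc1`, and its difference from compound 2 is this: 4-fluorophenyl in place of 3-fluorophenyl on a sulfur. Put simply, it carries 4-fluorophenyl in place of 3-fluorophenyl on a sulfur. Going by the values given here, one measured step bears on this change, as it also exchanges the group on a sulfur: a number 3 percentage points higher from compound 1 to compound 3 (within the scatter). Among the compounds with values here, that step involves other groups, and no measured pair exchanges these two, so it offers only indirect guidance. With nothing larger to go on, no change beyond the scatter is expected in this assay. The estimated step is a number 1.5 percentage points higher from compound 2 to compound 4 (within the scatter). For compound 4 the estimate is 7%, with an expected range from 0% to 16%.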

Compound 4, percent growth inhibition at one concentration: 13.5%
For compound 4 the middle estimate is 6.5 percentage points below the measured one, and the stated range covers the measured number.
By their numbers in this assay, from the lowest: compounds 2, 1, 3 and 4 (each within the scatter of the next).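

In this assay, for the compounds shown here, this is the first measured pair in which only the place of the fluorine differs, 4-fluorophenyl in place of 3-fluorophenyl on a sulfur, with the same atoms in both groups, and it gives a number 8 percentage points higher from compound 2 to compound 4 (within the scatter). Together with a number 3 percentage points higher from compound 1 to compound 3 (within the scatter), it means that neither of the two exchanges measured on the sulfur goes beyond the scatter, and no compound shown goes against this. Nothing available bears on the size of this step.

From the compounds shown here alone, it remains open whether an amine or a carboxylic acid on the ring in place of the fluorine would give a step beyond the scatter. Also open, going by these compounds, is whether a longer chain in place of the saturated chain carbon on the sulfur would do so.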